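This account rests on a few compounds, and the source may have more. Where it says the series, first, only, none or still open, it means among the compounds named here.

Compounds 1 to 3 are tested in a functional assay on HeLa cells (Homo sapiens) for cytotoxicity, read by sulforhodamine B assay, with a stated time of 48 h; a lower number here means a stronger inhibitor, a higher number a weaker inhibitor. Compound 1 `COc1ccc(/C=C/C(=O)/C=C/C2=C(C)CCCC2(C)C)cc1OC` gives 85000 nM in this assay. Compound 2 `COc1cc(/C=C/C(=O)/C=C/C2=C(C)CCCC2(C)C)cc(OC)c1OC` gives 73200 nM in this assay. The change methoxy in place of hydrogen on an aromatic carbon thus makes a step of a 1.2-fold lower number from compound 1 to compound 2 (0.06 log units; within the scatter). Compound 3 `CC1=C(/C=C/C(=O)/C=C/C=C/c2ccccc2)C(C)(C)CCC1` reaches only > 100000 nM in this assay, which is a limit of the assay and not a number. The difference between the core of compound 3 and the core of compound 1 is not broken down here. Compound 4 `COc1ccccc1/C=C/C=C/C(=O)/C=C/C1=C(C)CCCC1(C)C` has not yet been tested in this assay; it differs from compound 3 by methoxy in place of hydrogen on an aromatic carbon. This is the same kind of change as that from compound 1 to compound 2, but the surroundings differ: in compound 2 the entering methoxy sits ortho to a methoxy group, meta to a large group and meta to a methoxy group, whereas in compound 4 it sits ortho to a large group. The earlier step lay within the scatter, and compound 3 sits at the limit of > 100000 nM in this assay, at which 1 of the 3 values shown sits, so the step from compound 3 to compound 4 is expected to be about a step that the limit leaves unreadable from compound 3 to compound 4. Compound 4 is therefore expected to give about 110000 nM in this assay, somewhere between 50000 nM and 300000 nM, with a further limit the likelier report.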

Compound 4, half-maximal inhibitory concentration: 33500 nM
Estimate against measurement, compound 4: 3.3-fold (0.52 log units) above; the whole stated range lies above it.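

Carried to the core of compound 3, methoxy in place of hydrogen on an aromatic carbon gives an at least 2.9-fold lower number from compound 3 to compound 4 (0.47 log units; beyond the scatter) in this assay, and here the methoxy enters ortho to a large group. Going by these compounds, compound 3 stands at > 100000 nM, which is a limit of the assay and not a number, so the full size of this step stays unknown. The step does show that this change can go beyond the scatter in this series, but two pairs give no rule for carrying it from core to core, and they cannot be said to agree or to differ: the same change on two cores in this assay, a 1.2-fold lower number (0.06 log units; within the scatter) from compound 1 to compound 2 and an at least 2.9-fold lower number (0.47 log units; beyond the scatter) from compound 3 to compound 4; the limit leaves it open whether they differ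

The compounds shown leave open whether a hydroxyl group, an amine or a carboxylic acid in place of this methoxy would move the number. They also leave open whether methoxy at another place on the ring of compound 4 would give a like step.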